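The compounds below may be only part of what the source reports. "The series", "measured", "known", "first", "only" and "open" are said of these compounds alone.

Measured so far in a functional assay on B16-F10 cells (Mus musculus) for antiproliferative activity, read by CCK-8 assay, with a stated time of 48 h; on this read-out lower numbers stand for stronger inhibition and higher numbers for weaker inhibition:
- compound 1 `COc1ccc(/C=C\c2cc(OC)c(OC)c(OC)c2)cc1OCc1ccc(CN2CCCCC2C(=O)O)cc1`: > 10000 nM
- compound 2 `COc1ccc(/C=C\c2cc(OC)c(OC)c(OC)c2)cc1OCc1ccc(CNCCN(C)C)cc1`: > 10000 nM

Compound 2 stands only at a limit of this assay, > 10000 nM, and not at a number. Compound 1 is likewise a limit, > 10000 nM. Among the measured compounds shown here, the series so far therefore sits at the limit of > 10000 nM in this assay, at which 2 of the 2 values shown sit.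

Compound 3 `COc1ccc(/C=C\c2cc(OC)c(OC)c(OC)c2)cc1OCc1ccc(CN[C@H](C(=O)O)[C@@H](C)O)cc1` carries 1-carboxy-2-hydroxypropyl in place of 2-(dimethylamino)ethyl on an amine nitrogen. For the measured compounds named here, the one measured step is a step that the two limits leave unreadable from compound 1 to compound 2, so it offers no size to carry over. Going by the values given here, no measured compound in this set gives a number to anchor a direction. The expectation therefore rests on compound 2, with its limit of > 10000 nM. The estimated step is a step that the limit leaves unreadable from compound 2 to compound 3, with no clear change expected, and a further limit is the likeliest report. For compound 3 the expected value is 15000 nM, with an estimated range of 6000 nM to 40000 nM.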

Compound 3, half-maximal inhibitory concentration: 5400 nM
For compound 3 the middle estimate is 2.8-fold (0.44 log units) above the measured one, outside the stated range (below it).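

In this assay compound 3 is the only compound shown that gives a number rather than a limit, so a change on the amine nitrogen now has a readable lower bound. Placing 1-carboxy-2-hydroxypropyl there in place of 2-(dimethylamino)ethyl gives an at least 1.8-fold lower number from compound 2 to compound 3 (0.26 log units; that floor lies within the scatter), and the comparison with the 2-carboxypiperidin-1-yl compound gives an at least 1.8-fold lower number from compound 1 to compound 3 (0.26 log units; that floor lies within the scatter), so both floors stay within the scatter and the true sizes remain unknown. The rest of the series stays at the limit: the limit of > 10000 nM in this assay, at which 2 of the 3 values shown sit.

Still open, from the compounds shown here alone, is which part of 1-carboxy-2-hydroxypropyl goes with the lower number: a 2-hydroxypropyl group without the carboxylic acid, or a carboxymethyl group without the hydroxyl, would separate the two. The compounds shown also leave open what the two defined stereocentres contribute.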